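This account rests on a few compounds, and the source may have more. Where it says the series, first, only, none or still open, it means among the compounds named here.

Compound 1, `Cc1nc(N)sc1CCCN/C(N)=N/C(=O)NC1CCCCC1`, gives 389 nM in a functional assay on HEK293T cells for agonist activity at histamine H2 receptor (Homo sapiens), read by beta-arrestin recruitment; on this read-out lower numbers stand for an effect already at smaller amounts and higher numbers for an effect only at larger amounts of compound.
Compound 2, `Cc1nc(N)sc1CCCN/C(N)=N/C(=O)NC(C)c1cccc(F)c1`, gives 64.6 nM in this assay.
Compound 3, `Cc1nc(N)sc1CCCN/C(N)=N/C(=O)NCC(C)CCc1ccccc1`, gives 355 nM in this assay.

All three compounds share one core and differ only in the group carried on the amide-type nitrogen at the far end. On the numbers above, compound 1 stands at the highest value of the three. Compound 3 sits within the usual scatter of it, so the two cannot be told apart. Compound 2 is the only one clearly set apart, with a number well below that of compound 1.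

The step considered here leads from compound 1 to compound 4, `Cc1nc(N)sc1CCCN/C(N)=N/C(=O)Nc1ccccc1`. The change is phenyl in place of cyclohexyl on an amide-type nitrogen. The ring keeps its size and its carbon-only make-up; what changes is that a non-aromatic ring gives way to an aromatic one.

Among the measured compounds shown here, no measured pair shows exactly this exchange, so the expected size of the step in this assay rests on a guess. Compound 2 and compound 3 both carry an aromatic ring in this region and give values no higher than compound 1, so a step toward a somewhat lower number, though possibly still inside the scatter, is expected: a 1.6-fold lower number from compound 1 to compound 4 (0.19 log units; within the scatter). Compound 4 is therefore estimated at 250 nM, with a likely range from 60 nM to 1000 nM.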

Compound 4, half-maximal effective concentration: 3390 nM
Beside the measured number, compound 4's estimate is 14-fold (1.13 log units) below it, outside the stated range (above it).
By their numbers in this assay, from the lowest: compound 2; then compounds 3 and 1 (each within the scatter of the next); then compound 4.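

In this assay, the step from cyclohexyl to phenyl on an amide-type nitrogen is an 8.7-fold higher number from compound 1 to compound 4 (0.94 log units; beyond the scatter), so this position responds clearly to the exchange of a non-aromatic ring for an aromatic one, even though the ring size and the count of heavy atoms stay the same. An aromatic ring in this part of the molecule does not by itself bring a high number: compound 2 also carries one, but not directly on that nitrogen, and gives 64.6 nM, whereas compound 4 is the only one of the four with its aromatic ring directly on the nitrogen and has the highest number. Among the compounds shown here, nothing available here explains why this exchange moves the number so far.

The compounds shown leave open whether a benzyl group or a pyridyl ring on the same nitrogen would give a number closer to that of compound 2 or to that of compound 4. They also leave open whether a fluorine or a methoxy group on the phenyl ring of compound 4 would shift its number in either direction.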